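Series notes: triazole substituent variation and cytotoxicity on fibroblasts

The compounds below may be only part of what the source reports. "The series", "measured", "known", "first", "only" and "open" are said of these compounds alone.

Measured compounds:
compound 1 `O=C1O[C@H]([C@@H](O)Cn2cc(-c3cccc(O)c3)nn2)C(OCc2ccccc2)=C1OCc1ccccc1`: 39000 nM
compound 2 `COc1ccccc1-c1cn(C[C@H](O)[C@H]2OC(=O)C(OCc3ccccc3)=C2OCc2ccccc2)nn1`: 50 nM
compound 3 `O=C1O[C@H]([C@@H](O)Cn2cc(C3CC3)nn2)C(OCc2ccccc2)=C1OCc1ccccc1`: 24300 nM

In an ADME assay on HFF cells (Homo sapiens) for cytotoxicity, read by MTT assay, with a stated time of 72 h (a higher number here means a weaker inhibitor, a lower number a stronger inhibitor), compound 3 stands second highest of the three numbers. Its nearest neighbour is compound 1, and the step of a 1.6-fold lower number from compound 1 to compound 3 (0.21 log units; within the scatter) lies within the scatter, so the two cannot be ordered. Its furthest neighbour is compound 2, and the step of a 490-fold higher number from compound 2 to compound 3 (2.69 log units; beyond the scatter) is large and beyond the scatter.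

The next compound, compound 4 `O=C1O[C@H]([C@@H](O)Cn2cc(-c3ccc(Br)cc3)nn2)C(OCc2ccccc2)=C1OCc1ccccc1`, differs from compound 3 in one place: 4-bromophenyl in place of cyclopropyl on an aromatic carbon.

Among the compounds with values here, two measured steps bear on this change, both replacing a ring on the same aromatic carbon with cyclopropyl. From compound 1 the step of a 1.6-fold lower number from compound 1 to compound 3 (0.21 log units; within the scatter) was within the scatter; from compound 2 the step of a 490-fold higher number from compound 2 to compound 3 (2.69 log units; beyond the scatter) was large. Going back from cyclopropyl to a phenyl ring carrying bromine has therefore two precedents that disagree widely, one flat and one steep. The expected step of an 8.1-fold lower number from compound 3 to compound 4 (0.91 log units; beyond the scatter) is set between them, in the direction of a lower number, with a wide range to cover both outcomes.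

Compound 4 is therefore expected to give about 3000 nM in this assay, within 150 nM to 30000 nM.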

Compound 4, half-maximal inhibitory concentration: 5100 nM
For compound 4 the middle estimate is 1.7-fold (0.23 log units) below the measured one; the range from low to high includes it.
By their numbers in this assay, from the lowest: compound 2; then compound 4; then compounds 3 and 1 (each within the scatter of the next).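

In this assay, carrying a phenyl ring at this aromatic carbon does not by itself fix the number: a 4.8-fold lower number from compound 3 to compound 4 (0.68 log units; beyond the scatter) is beyond the scatter, whereas the earlier step between the 3-hydroxyphenyl and cyclopropyl compounds was not. The a 7.6-fold lower number from compound 1 to compound 4 (0.88 log units; beyond the scatter) also shows that compounds bearing different substituted phenyl rings can be told apart here, so the substituent and where it sits on that ring both remain in play, and 4-bromophenyl gives an intermediate result. Even so, a 100-fold higher number from compound 2 to compound 4 (2.01 log units; beyond the scatter) leaves compound 2 well apart from the other three compounds, so the 2-methoxyphenyl compound remains the exception in this small set, and no measurement offered here accounts for any of these steps.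

Still open, as far as these compounds go, is whether the low number of compound 2 comes from the methoxy group itself or from its place on the phenyl ring, and whether the bromine in compound 4 contributes anything beyond what a plain phenyl ring would give. Also open, from the compounds shown here alone, is how this position responds to a different kind of group, such as an amine or a carboxylic acid on the phenyl ring, or a longer alkyl chain in place of the ring.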